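A Thiophene Swapped for a Hydroxyphenyl Ring

The source may report more compounds than this note shows. Statements on the series, on what has been measured and on what is new or still open speak of the compounds shown alone.

Of the compounds shown here, two have so far been measured in a functional assay on DU-145 cells (Homo sapiens) for inhibition, read by trypan blue exclusion, with a stated time of 96 h; a higher number here means a weaker inhibitor of growth, a lower number a stronger inhibitor of growth. Compound 1, `COc1cc(OC)c(/C=C(\C(=O)c2ccc(Cl)cc2)S(=O)(=O)Cc2ccc(F)cc2)c(OC)c1`, gives 25000 nM. Compound 2, `COc1ccsc1/C=C(\C(=O)c1ccc(Br)cc1)S(=O)(=O)Cc1ccc(Cl)cc1`, gives 50000 nM. Compound 2 holds the highest of these two numbers, and its nearest neighbour is compound 1, whose number lies within the scatter of it, so the two cannot be separated on potency.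

Compound 3, `COc1ccc(/C=C(\C(=O)c2ccc(Br)cc2)S(=O)(=O)Cc2ccc(Cl)cc2)c(O)c1`, has not yet been measured in this assay. It differs from compound 2 in one place: 2-hydroxy-4-methoxyphenyl in place of 3-methoxythiophen-2-yl on a double-bonded chain carbon bound to a double-bonded chain carbon. Going by the values given here, no pair of measured compounds here differs by a single change, so the size of this step can only be judged from the two numbers that exist. Both sit at high concentrations, and compound 1, which also carries a six-membered aromatic ring of carbon only with methoxy groups in place of a thiophene, gives 25000 nM, which favours a modest move toward a lower number. The expected step is a 2.0-fold lower number from compound 2 to compound 3 (0.30 log units; within the scatter), small and not clearly beyond the scatter. Compound 3 is therefore estimated at 25000 nM, with a range from 8000 nM to 80000 nM.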

Compound 3, concentration for 50% growth inhibition: 10000 nM
Compound 3: middle estimate off by 2.5-fold (0.40 log units), on the high side; the range from low to high includes it.
By their numbers in this assay, from the lowest: compound 3; then compounds 1 and 2 (each within the scatter of the next).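

In this assay the change to 2-hydroxy-4-methoxyphenyl in place of 3-methoxythiophen-2-yl gives a 5.0-fold lower number from compound 2 to compound 3 (0.70 log units; beyond the scatter), the first single-place step available here, and it shows that the group on this double-bonded chain carbon can shift growth inhibition by more than the usual scatter. The step bundles several differences: a five-membered aromatic ring with one hetero atom gives way to a six-membered aromatic ring of carbon only, the group grows from 7 to 9 heavy atoms, and a hydrogen-bond donor appears where there was none. No measurement here bears on why the number falls, so the step records a change in growth inhibition and offers no explanation for it.

The compounds shown leave open which of these differences accounts for the step, since ring and hydroxy group change together between compound 2 and compound 3. Also open, from the compounds shown here alone, is how the position responds to other groups, such as an amine or a carboxylic acid in place of the hydroxy group on the 2-hydroxy-4-methoxyphenyl ring.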